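Benzylamino for ethoxy on the carbonyl: outlook for compound 4

A few compounds are considered here, and "the series" means these few. Any claim that something is new, unique, unknown or untested is made for them only; others in the source may bear on it.

Compound 1 `O=C(N[C@@H](CCC(=O)N1CCN(c2cccc(NC3=NCCN3)c2)CC1)C(=O)O)OCc1ccccc1` gives 3 nM in a functional assay (muscle tissue) for inhibition, with Homo sapiens as the target; a lower number here means a stronger inhibitor, a higher number a weaker inhibitor. Among the compounds with values here, compound 2 `O=C(N[C@@H](CCC(=O)N1CCN(c2cccc(NC3=NCCCCN3)c2)CC1)C(=O)O)OCc1ccccc1` gives 1.7 nM; the single one-point step measured so far, a 1.8-fold lower number from compound 1 to compound 2 (0.25 log units; within the scatter), sits on a nitrogen on the aromatic ring and lies within the scatter. Compound 3 `CCOC(=O)N[C@@H](CCC(=O)N1CCN(c2cccc(NC3=NCCCN3)c2)CC1)C(=O)O` gives 2.1 nM; among the three numbers it stands second highest, nearest to compound 2 and furthest from compound 1, with both gaps inside the scatter. The three measured compounds thus show no separation from one another.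

Compound 4 `O=C(NCc1ccccc1)N[C@@H](CCC(=O)N1CCN(c2cccc(NC3=NCCCN3)c2)CC1)C(=O)O` differs from compound 3 by benzylamino in place of ethoxy on a carbonyl carbon whose other neighbour is an amide-type nitrogen. Within the data shown here, no measured step touches this carbonyl: the one step available concerns the cyclic amidine ring on the aromatic nitrogen and was within the scatter. The measured compounds therefore give no ground for a step beyond the scatter in either direction, and the untested nature of the change only widens the range. Compound 4 is expected near 2.5 nM, between 0.7 nM and 9 nM. That corresponds to an expected step of a 1.2-fold higher number from compound 3 to compound 4 (0.08 log units; within the scatter).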

Compound 4, half-maximal inhibitory concentration: > 10 nM
Compound 4: only a limit was reported; the forecaster's own chance of this, stated with the estimate: 2%; at least 4.0-fold (0.60 log units) between middle value and limit.
By their numbers in this assay, from the lowest: compounds 2, 3 and 1 (each within the scatter of the next). At a limit, above all of these: compound 4.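

Benzylamino in place of ethoxy, on a carbonyl carbon whose other neighbour is an amide-type nitrogen, gives the first step in the series that clears the scatter in this assay (an at least 4.7-fold higher number from compound 3 to compound 4 (0.67 log units; beyond the scatter)). The only earlier step, on a nitrogen on an aromatic ring (a 1.8-fold lower number from compound 1 to compound 2 (0.25 log units; within the scatter)), stayed within the scatter, so this carbonyl position is the one place shown where a single change separates two compounds, and the direction is towards a higher number, meaning a weaker inhibitor. Compound 4 reads > 10 nM and that reading is a limit, not a number: the limit of > 10 nM in this assay, at which 1 of the 4 values shown sits.

From the compounds shown here alone, the size of the step therefore stays open beyond its printed lower bound, and so does its source, as the change swaps the linking oxygen for a nitrogen and the ethyl for a benzyl group in one move. Ethylamino on the same carbonyl carbon would separate those two parts, and a longer chain such as phenethylamino would show whether the position responds to the length of the group.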